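Ring-methyl position on the anilide of the shared core

This account rests on a few compounds, and the source may have more. Where it says the series, first, only, none or still open, it means among the compounds named here.

Measured so far in a functional assay on the whole organism for inhibition, with Rattus norvegicus as the target, read by cytopathic effect and paw edema, at a dose of 100 mg/kg by the oral route; on this read-out lower numbers stand for less inhibition and higher numbers for more inhibition at the one dose given (going by the name of the read-out):
Compound 1 `O=C(NC1CCN(Cc2ccccc2)CC1)c1c(O)c2cccnc2n(-c2ccccc2)c1=O`: 1.2%
Compound 2 `Cc1ccc(NC(=O)c2c(O)c3cccnc3n(-c3ccccc3)c2=O)cc1`: 2.2%
Compound 3 `O=C(Nc1ccc([N+](=O)[O-])cc1)c1c(O)c2cccnc2n(-c2ccccc2)c1=O`: -25.8%

Compound 2 has the largest number of the three; compound 1 lies within the scatter of it, so the two cannot be ordered. For the measured compounds named here, the one step beyond the scatter is a number 28 percentage points lower from compound 2 to compound 3 (beyond the scatter), a nitro in place of a methyl on the aromatic carbon.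

Compound 4 `Cc1ccccc1NC(=O)c1c(O)c2cccnc2n(-c2ccccc2)c1=O` is not yet measured. It differs from compound 2 by 2-methylphenyl in place of 4-methylphenyl on an amide-type nitrogen; the two hold the same atoms joined differently. Going by the values given here, no measured step moves a methyl around the ring; the step from compound 2 to compound 3 swaps one group for another and bears on this change only in showing that a change on this ring can move the number downward. With no closer guide, the expectation for compound 4 is a step of a number 1.2 percentage points lower from compound 2 to compound 4 (within the scatter), within the scatter. Compound 4 is thus estimated at 1%, with a range from -20% to 20%.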

Compound 4, a percentage reported as inhibition, in the whole organism at one dose (the size of the read-out at that dose, not a potency): 9.8%
The estimate for compound 4 lay 8.8 percentage points below the measured number; measured number inside the range.
By their numbers in this assay, from the lowest: compound 3; then compounds 1, 2 and 4 (each within the scatter of the next).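

Notes on the anilide position: in this assay the move from 4-methylphenyl to 2-methylphenyl on the amide-type nitrogen gives a number 7.6 percentage points higher from compound 2 to compound 4 (within the scatter) and so does not separate the two methyl placements on this read-out. The gap to the nitro compound holds after the methyl moves, with a number 35.6 percentage points higher from compound 3 to compound 4 (beyond the scatter) as the step, so on these compounds the split lies between 4-nitrophenyl and either methylphenyl, not between the two methylphenyl groups. No measurement at hand speaks to the reason for these numbers.

Going by these compounds, it remains open whether 2-nitrophenyl would share the low number of compound 3 or fall with compound 2 and compound 4. Also open, on these data alone, is whether a chlorine atom, an amine or a carboxylic acid on this ring would lift the number beyond the scatter of compound 2.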